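This account rests on a few compounds, and the source may have more. Where it says the series, first, only, none or still open, it means among the compounds named here.

Compound 1, with structure `COc1cc(/C=C/C(=O)/C=C(/C=C/c2ccc(OC(C)=O)c(OC)c2)NC2CCCCC2)ccc1OC(C)=O`, and compound 2, with structure `COc1cc(/C=C/C(=O)/C=C(/C=C/c2ccc(OC(C)=O)c(OC)c2)NCC(C)C)ccc1OC(C)=O`, share a core carrying acetylated phenols. In a functional assay on HT-29 cells (Homo sapiens) for inhibition, read by sulforhodamine B assay, with a stated time of 72 h (on this read-out lower numbers stand for stronger inhibition and higher numbers for weaker inhibition), compound 1 gives only a limit, > 25000 nM. In this assay compound 2 likewise gives only a limit, > 25000 nM. The change from compound 1 to compound 2 is isobutyl in place of cyclohexyl on an amine nitrogen, and because both values sit at the limit of > 25000 nM in this assay, at which 3 of the 3 values shown sit, the step that the two limits leave unreadable from compound 1 to compound 2 cannot be read. Compound 3, with structure `COc1cc(/C=C/C(=O)/C=C(/C=C/c2ccc(O)c(OC)c2)NC2CCCCC2)ccc1O`, carries the free phenols instead; how its core differs from that of compound 1 is not broken down here. In this assay compound 3 also gives only a limit, > 25000 nM. Compound 4, with structure `COc1cc(/C=C/C(=O)/C=C(/C=C/c2ccc(O)c(OC)c2)NCC(C)C)ccc1O`, is not yet measured. The change from compound 3 to compound 4 is isobutyl in place of cyclohexyl on an amine nitrogen, the same change as from compound 1 to compound 2, at the same place. Since the step from compound 1 to compound 2 stayed at the limit of > 25000 nM in this assay, at which 3 of the 3 values shown sit, the step that the limit leaves unreadable from compound 3 to compound 4 from compound 3 to compound 4 is expected to leave compound 4 at the limit as well. Compound 4 is therefore estimated at 40000 nM, within 15000 nM to 120000 nM.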

Compound 4, half-maximal inhibitory concentration: 24000 nM
Beside the measured number, compound 4's estimate is 1.7-fold (0.22 log units) above it; measured number inside the range.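

In this assay, isobutyl in place of cyclohexyl on the amine nitrogen of the free-phenol core gives an at least 1.0-fold lower number from compound 3 to compound 4 (0.01 log units; that floor lies within the scatter), so this step shows no change beyond the scatter. The same change on the core with the acetylated phenols cannot be read, and the two cores cannot be compared for it, because the values involved sit at a limit: the limit of > 25000 nM in this assay, at which 3 of the 4 values shown sit. These results therefore do not show that the change carries from one core to the other, nor that it fails to carry, since a real shift hidden by the limit and no shift at all both fit them.

The compounds shown leave open whether any group on the amine nitrogen can give a number well clear of the limit in this assay. A benzyl group, a longer chain or a chain ending in a carboxylic acid could each be tested on both cores, and readable values on both would allow a true comparison of the same change.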